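This account rests on a few compounds, and the source may have more. Where it says the series, first, only, none or still open, it means among the compounds named here.

Compound 1, `Cc1n[nH]c(-c2ccccc2NCC2=NCCN2)n1`, gives in an in vitro functional assay on cells (Fibroblast) for agonist activity at Alpha-1D adrenergic receptor (Homo sapiens) (on this read-out lower numbers stand for an effect already at smaller amounts and higher numbers for an effect only at larger amounts of compound), only a limit of the assay, < 5020 nM.
Compound 2, `Cn1nccc1-c1ccccc1NCC1=NCCN1`, likewise gives only a limit of the assay, < 100000 nM.
Compound 3, `Cn1cccc1-c1ccccc1NCC1=NCCN1`, gives 251 nM.

Among the three measured compounds, compound 3 thus stands as the only one with an actual number in this assay; the other two values are limits. The step under consideration runs from compound 3 to compound 4, `Cn1ccnc1-c1ccccc1NCC1=NCCN1`, and consists of 1-methyl-1H-imidazol-2-yl in place of 1-methyl-1H-pyrrol-2-yl on an aromatic carbon. Of the measured steps, a step that the two limits leave unreadable from compound 1 to compound 2, a step that the limit leaves unreadable from compound 1 to compound 3 and a step that the limit leaves unreadable from compound 2 to compound 3 each involve at least one compound whose value is a limit, so their sizes cannot be read; this is because the limit of < 100000 nM in this assay, at which 1 of the 3 values shown sits, and the limit of < 5020 nM in this assay, at which 1 of the 3 values shown sits, are all that compound 1 and compound 2 give. Among the compounds with values here, none of the measured steps therefore tells how swapping one five-membered group for another moves the read-out here.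

With no readable step to lean on, compound 4 is expected to stay close to compound 3, and the step from compound 3 to compound 4 is estimated at a 1.6-fold higher number from compound 3 to compound 4 (0.20 log units; within the scatter). Compound 4 is accordingly estimated at 400 nM, with an expected range from 100 nM to 1600 nM.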

Compound 4, half-maximal effective concentration: 200 nM
Compound 4: middle estimate off by 2.0-fold (0.30 log units), on the high side; low and high end bracket the measured number.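

Within the data shown here, for the first time a step at this place can be read: on an aromatic carbon of a six-membered aromatic ring of carbon only, ortho to a group of 7 heavy atoms, 1-methyl-1H-imidazol-2-yl in place of 1-methyl-1H-pyrrol-2-yl gives a 1.3-fold lower number from compound 3 to compound 4 (0.10 log units; within the scatter) in this assay. Compound 3 and compound 4 therefore stand level on this read-out, although the entering ring has 2 hetero atoms and 2 hydrogen-bond acceptors and the leaving ring has 1 hetero atom and 1 hydrogen-bond acceptor. At this place, then, one ring carbon of the 1-methyl-1H-pyrrol-2-yl group can give way to a nitrogen, as 1-methyl-1H-imidazol-2-yl, with no readable shift in the number.

The steps to compound 4 from compound 2 and from compound 1 cannot be read, because each starts from a limit of the assay, in the case of compound 2: the limit of < 100000 nM in this assay, at which 1 of the 4 values shown sits. Compound 1 likewise gives only a limit, and how a phenyl or a thiophen-2-yl group would read at this place also stays open: the limit of < 5020 nM in this assay, at which 1 of the 4 values shown sits.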